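From Ethoxy to Phenoxy: What Compound 4 Might Dissolve

The source may report more compounds than this note shows. Statements on the series, on what has been measured and on what is new or still open speak of the compounds shown alone.

Measured compounds:
Compound 1, `CCOc1cc(-c2ccnc(N)n2)cc2[nH]nc(N)c12`: in a physicochemical assay for solubility, read by LC-MS, in phosphate buffer, measured as kinetic solubility, with a stated time of 24 h, at 25 degrees C, at pH 7.4 (a higher number here means a more soluble compound, a lower number a less soluble compound), compound 1 gives 861000 nM.
Compound 2, `Nc1nccc(-c2ccc3c(Nc4ccccc4)n[nH]c3c2)n1`: compound 2 gives 3000 nM.
Compound 3, `Nc1cc(-c2ccc3cn[nH]c3c2)ncn1`: compound 3 gives 332000 nM.

Among these three, compound 1 stands highest in this assay. Compound 3 is the nearest to it and compound 2 the furthest, and both gaps lie beyond the scatter of the assay. Compound 4, `Nc1nccc(-c2cc(Oc3ccccc3)c3c(N)n[nH]c3c2)n1`, differs from compound 1 in a single place: phenyl in place of ethyl on an oxygen on an aromatic ring. For the measured compounds named here, no pair of measured compounds differs by one change, so the size of this step cannot be read from a precedent within the set. What the set does show is that compound 2, which also bears a phenyl, gives 3000 nM and so sits far from the other two, at the low end of the set. The step from compound 1 to compound 4 is therefore expected to point downward and to exceed the scatter, an 11-fold lower number from compound 1 to compound 4 (1.03 log units; beyond the scatter). Compound 4 is estimated at 80000 nM, with a plausible range from 15000 nM to 400000 nM.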

Compound 4, solubility: 117000 nM
For compound 4 the middle estimate is 1.5-fold (0.17 log units) below the measured one; the measured number falls inside the stated range.
By their numbers in this assay, from the lowest: compound 2; then compound 4; then compound 3; then compound 1.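

In this assay, phenyl in place of ethyl on an oxygen on an aromatic ring gives a 7.4-fold lower number from compound 1 to compound 4 (0.87 log units; beyond the scatter), the first measure in this set of a single change. The step is beyond the scatter, and it is modest in size: with a ring of six carbons in place of a two-carbon ethyl, compound 4 still gives 117000 nM. No measurement shown offers a reason for this step.

From the compounds shown here alone, this reading rests on one pair, so it remains open whether ethoxy to phenoxy would give a step of similar size on any other core. Also open, going by these compounds, is how this assay would read with a longer chain on this oxygen, with a phenyl carrying an amine or a carboxylic acid, or with an amine in place of the oxygen itself.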